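Compound 3 to compound 4: 1-hydroxycyclohexyl enters

The source may report more compounds than this note shows. Statements on the series, on what has been measured and on what is new or still open speak of the compounds shown alone.

In an ADME assay on HepG2 cells (Homo sapiens) for cytotoxicity, read by MTT assay, with a stated time of 72 h (on this read-out lower numbers stand for higher toxicity in this test and higher numbers for lower toxicity in this test), compound 1 (`Nc1ccc(C#Cc2cc(Cl)cn3c([N+](=O)[O-])c(CS(=O)(=O)c4ccccc4)nc23)cc1`) gives only a limit, > 3900 nM. Compound 2 (`O=[N+]([O-])c1c(CS(=O)(=O)c2ccccc2)nc2c(C#Cc3ccc(CO)cc3)cc(Cl)cn12`) also gives only a limit, > 15600 nM. Compound 3 (`O=[N+]([O-])c1c(CS(=O)(=O)c2ccccc2)nc2c(C#CC3(O)CCCC3)cc(Cl)cn12`) stands at a limit too, > 31300 nM, and so has no numerical value.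

Compound 4 (`O=[N+]([O-])c1c(CS(=O)(=O)c2ccccc2)nc2c(C#CC3(O)CCCCC3)cc(Cl)cn12`) carries 1-hydroxycyclohexyl in place of 1-hydroxycyclopentyl on a triple-bonded carbon.

The nearest measured changes are a step that the two limits leave unreadable from compound 1 to compound 3 and a step that the two limits leave unreadable from compound 2 to compound 3, so neither gives a size to carry over. No shift beyond the scatter is therefore expected in this assay, and no direction is favoured. The estimated change is an at least 1.1-fold lower number from compound 3 to compound 4 (0.04 log units; that floor lies within the scatter). Compound 4 is expected at 28000 nM, within an estimated range of 10000 nM to 60000 nM.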

Compound 4, half-maximal cytotoxic concentration: > 25000 nM
Compound 4 gave a limit, no number; the forecaster's own chance of this, stated with the estimate: 80%; the middle value lies beyond the limit too.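

Going by these compounds alone, compound 4, like compound 1, compound 2 and compound 3, gives only a limit, so no step among them can be read. The compounds shown leave open how these groups on the triple-bonded carbon rank for cytotoxicity.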